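Serine side chain in place of glutamine: compound 3

The source may hold more compounds than are shown below. What is called first, only, known or untested is meant among the compounds shown, and "the series" means these compounds.

compound 1 `NC(=O)CC[C@H](NC(=O)CN(c1ncnc2c1ncn2C1CCCCO1)C1CC1)C(=O)OCc1ccccc1`: 47%
compound 2 `NCCCC[C@H](NC(=O)CN(c1nc(Cl)nc2[nH]cnc12)C1CC1)C(=O)OCc1ccccc1`: 26.1%

In a functional assay on the whole organism (Tail, strain ICR) with Mus musculus as the target, in the tail flick test, with a stated time of 30 min, at a dose of 25 umol/kg by the oral route (on this read-out lower numbers stand for a weaker effect and higher numbers for a stronger effect at the one dose given), compound 1 gives 47%, the highest of the two numbers shown. Compound 2 gives 26.1%, beyond the scatter below compound 1, but the two differ in several places and no single-change step is shown between them. Compound 3 `O=C(CN(c1ncnc2c1ncn2C1CCCCO1)C1CC1)N[C@@H](CO)C(=O)OCc1ccccc1` is not yet measured. It differs from compound 1 by hydroxy in place of carbamoylmethyl on a saturated chain carbon, two bonds along the chain from an amide-type nitrogen and a carbonyl carbon. Going by the values given here, no measured step of this kind exists; a modest downward step a number 12 percentage points lower from compound 1 to compound 3 (beyond the scatter) is expected. Compound 3 is estimated at 35%, in the range 15% to 55%.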

Compound 3, a percentage reported as activity, at one dose (the size of the read-out at that dose, not a potency): 27.8%
Beside the measured number, compound 3's estimate is 7.2 percentage points above it; measured number inside the range.
By their numbers in this assay, from the lowest: compounds 2 and 3 (each within the scatter of the next); then compound 1.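

Swapping 2-carbamoylethyl for hydroxymethyl gives the first single-change step in the series: in this assay it reads a number 19.2 percentage points lower from compound 1 to compound 3 (beyond the scatter), with the rest of the structure unchanged. This carbon therefore does not tolerate every side chain equally, and the carbamoylmethyl-bearing chain of compound 1 is the better of the two shown. Nothing measured here accounts for the step.

Chain length and end group change together in this step, so their separate contributions stay open. Also open, going by these compounds, is how an amine, a carboxylic acid or a longer chain on this carbon would compare with compound 1.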